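Dropping the Chloro from a Chalcone Ether

A few compounds are considered here, and "the series" means these few. Any claim that something is new, unique, unknown or untested is made for them only; others in the source may bear on it.

Within the data shown here, compound 1, `O=C(COc1ccc(C(=O)/C=C/c2ccccc2Cl)cc1)N[C@H]1CCOC1=O`, is the only member of this set with a measured number: in a functional assay on PC-3 cells (Homo sapiens) for antiproliferative activity, read by MTT assay, with a stated time of 72 h (a lower number here means a stronger inhibitor, a higher number a weaker inhibitor), compound 1 gives 4610 nM. Compound 2, `O=C(CNc1ccc(Cl)cc1Cl)N[C@H]1CCOC1=O`, reaches only a limit of the assay in this assay, > 64000 nM. Compound 3, `O=C1OCC[C@@H]1NC(=S)SCCOc1cccc2ccccc12`, likewise reaches only a limit in this assay, > 64000 nM. Among the measured compounds shown here, both sit at the limit of > 64000 nM in this assay, at which 2 of the 3 values shown sit, so compound 1 stands alone as the one compound with a real reading.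

Compound 4, `O=C(COc1ccc(C(=O)/C=C/c2ccccc2)cc1)N[C@H]1CCOC1=O`, differs from compound 1 by a single change: hydrogen in place of chloro on an aromatic carbon. For the measured compounds named here, no measured pair of compounds shows the effect of such a change here, so the step from compound 1 to compound 4 is expected to be small, a 1.3-fold higher number from compound 1 to compound 4 (0.11 log units; within the scatter), not beyond the usual scatter. Compound 4 is therefore estimated at 6000 nM, within 2500 nM to 15000 nM.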

Compound 4, half-maximal inhibitory concentration: 56800 nM
The estimate for compound 4 lay 9.5-fold (0.98 log units) below the measured number; the measured number lies above the stated range.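

Among these compounds, this is the first measured pair in the set, and it shows that a single atom at this place matters: hydrogen in place of chloro gives a 12-fold higher number from compound 1 to compound 4 (1.09 log units; beyond the scatter) in this assay. So the 2-chlorophenyl group of compound 1 carries much of its activity, more than a one-atom change might suggest. Compound 4 still gives a reading, but it lies close to where compounds 2 and 3 stop giving one: the limit of > 64000 nM in this assay, at which 2 of the 4 values shown sit.

As far as these compounds go, whether a fluoro, a methyl or an amine on this aromatic carbon, ortho to a large group, would keep the activity remains open.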